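From benzoyl to (4-methoxyphenyl)carbonyl on the shared core

This account rests on a few compounds, and the source may have more. Where it says the series, first, only, none or still open, it means among the compounds named here.

In a functional assay on Bel-7402 cells (Homo sapiens) for cytotoxicity, read by MTT assay, with a stated time of 72 h (a higher number here means a weaker inhibitor, a lower number a stronger inhibitor), compound 1 (`C=C1C(=O)[C@@]23C(=O)OC[C@]4(C(=O)CCC(C)(C)[C@H]4C=O)[C@@H]2CC[C@@H]1[C@H]3O`) gives 5030 nM as the free hydroxyl form. Compound 2 (`C=C1C(=O)[C@@]23C(=O)OC[C@]4(C(=O)CCC(C)(C)[C@H]4C=O)[C@@H]2CC[C@@H]1[C@H]3OC(=O)CC`) with its propanoyl group gives 1650 nM on the same scale, and compound 3 (`C=C1C(=O)[C@@]23C(=O)OC[C@]4(C(=O)CCC(C)(C)[C@H]4C=O)[C@@H]2CC[C@@H]1[C@H]3OC(=O)c1ccccc1`) with its benzoyl group gives 1850 nM on that scale too. The steps from the free hydroxyl form are modest but beyond the scatter (a 3.0-fold lower number from compound 1 to compound 2 (0.48 log units; beyond the scatter) and a 2.7-fold lower number from compound 1 to compound 3 (0.43 log units; beyond the scatter)). Phenyl in place of ethyl on the carbonyl carbon shifts nothing beyond the scatter (a 1.1-fold higher number from compound 2 to compound 3 (0.05 log units; within the scatter)). Compound 3 thus stands level with compound 2 and clearly under compound 1.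

Compound 4 (`C=C1C(=O)[C@@]23C(=O)OC[C@]4(C(=O)CCC(C)(C)[C@H]4C=O)[C@@H]2CC[C@@H]1[C@H]3OC(=O)c1ccc(OC)cc1`) has methoxy in place of hydrogen on an aromatic carbon, para to a large group (methoxy in place of hydrogen on an aromatic carbon). Among the measured compounds shown here, no measured step touches that aromatic ring, so the closest guide is the exchange within the acyl group (a 1.1-fold higher number from compound 2 to compound 3 (0.05 log units; within the scatter)), and no shift beyond the scatter is expected. The expected value for compound 4 is 1800 nM (estimated range 850 nM to 3400 nM). The estimated step stays within the scatter (a 1.0-fold lower number from compound 3 to compound 4 (0.01 log units; within the scatter)).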

Compound 4, half-maximal inhibitory concentration: 2800 nM
Beside the measured number, compound 4's estimate is 1.6-fold (0.19 log units) below it; low and high end bracket the measured number.
By their numbers in this assay, from the lowest: compounds 2, 3, 4 and 1 (each within the scatter of the next, the first and the last beyond it).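

In this assay, among the compounds shown here, methoxy on an aromatic carbon, para to a large group, is the first change on the ring of the acyl group, and it stays within the scatter (a 1.5-fold higher number from compound 3 to compound 4 (0.18 log units; within the scatter)), as does 4-methoxyphenyl in place of ethyl on the carbonyl carbon (a 1.7-fold higher number from compound 2 to compound 4 (0.23 log units; within the scatter)). The new point concerns acylation of the oxygen: the propanoyl and benzoyl steps lie beyond the scatter (a 3.0-fold lower number from compound 1 to compound 2 (0.48 log units; beyond the scatter); a 2.7-fold lower number from compound 1 to compound 3 (0.43 log units; beyond the scatter)), whereas the (4-methoxyphenyl)carbonyl step does not (a 1.8-fold lower number from compound 1 to compound 4 (0.25 log units; within the scatter)), so compound 4 goes against any rule that acylation here clears the scatter. No supporting data bear on this result.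

Open, from the compounds shown here alone, is whether an amine or a carboxylic acid on that aromatic ring, or a longer chain in place of ethyl, would move the number beyond the scatter.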